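Ortho and meta isomers against alpha glucosidase

A few compounds are considered here, and "the series" means these few. Any claim that something is new, unique, unknown or untested is made for them only; others in the source may bear on it.

Measured so far:
compound 1 `O=C1NC(=O)/C(=C/c2cccc(OCN3C(=O)c4ccccc4C3=O)c2)S1`: > 100000 nM
compound 2 `O=C1NC(=O)/C(=C/c2ccccc2OCN2C(=O)c3ccccc3C2=O)S1`: > 100000 nM
compound 3 `O=C1NC(=S)S/C1=C\c1cccc(OCN2C(=O)c3ccccc3C2=O)c1`: 34000 nM

The three measured compounds share a phthalimide-bearing side chain on a benzylidene core and differ in the five-membered ring at its end or in where the side chain sits. In an assay on isolated protein for inhibition of Alpha glucosidase (Homo sapiens), read by spectrophotometry, with stated times of 15 min and 30 min (on this read-out lower numbers stand for stronger inhibition and higher numbers for weaker inhibition), compound 1 gives only a limit, > 100000 nM. Compound 2 likewise gives only a limit in this assay, > 100000 nM. Among the compounds with values here, compound 3 is the one compound with a number, 34000 nM in this assay.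

Within the data shown here, the one counted change is a group of 8 heavy atoms (4 carbon, 1 nitrogen, 1 oxygen, 2 sulfur; one five-membered non-aromatic ring with 2 hetero atoms) in place of a group of 8 heavy atoms (4 carbon, 1 nitrogen, 2 oxygen, 1 sulfur; one five-membered non-aromatic ring with 2 hetero atoms), on an aromatic carbon, and it makes an at least 2.9-fold lower number from compound 1 to compound 3 (0.46 log units; beyond the scatter). This step rests on (the limit of > 100000 nM in this assay, at which 2 of the 3 values shown sit), so its true size is open at the upper end.

Compound 4 `O=C1NC(=S)S/C1=C\c1ccccc1OCN1C(=O)c2ccccc2C1=O` has not been measured in this assay. It stands to compound 2 as compound 3 stands to compound 1: the change is a group of 8 heavy atoms (4 carbon, 1 nitrogen, 1 oxygen, 2 sulfur; one five-membered non-aromatic ring with 2 hetero atoms) in place of a group of 8 heavy atoms (4 carbon, 1 nitrogen, 2 oxygen, 1 sulfur; one five-membered non-aromatic ring with 2 hetero atoms), on an aromatic carbon. The two place lines are not the same, meta to a large group in the first pair and ortho to a large group in the second, so this is the same kind of change rather than the same change. How the core of compound 2 differs from the core of compound 1 is not broken down here.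

Resting on the step from compound 1 to compound 3, compound 4 is expected to move by an at least 2.5-fold lower number from compound 2 to compound 4 (0.39 log units; beyond the scatter) from the limit of compound 2 in this assay. Compound 4 is therefore estimated at 40000 nM, with a likely range from 15000 nM to 150000 nM, and a fair chance that only a limit is reported.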

Compound 4, half-maximal inhibitory concentration: > 100000 nM
Compound 4: a limit, no number; the forecaster's own chance of this, stated with the estimate: 35%; middle value at least 2.5-fold (0.39 log units) from the limit.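

Compound 4 gives only a limit in this assay, > 100000 nM. Compound 2 also gives only a limit, so no step from compound 2 to compound 4 can be read: the limit of > 100000 nM in this assay, at which 3 of the 4 values shown sit.

The compounds shown leave open whether the change that gave the lower number on going from compound 1 to compound 3 has any effect at all on the core of compound 2.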